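The source may report more compounds than this note shows. Statements on the series, on what has been measured and on what is new or still open speak of the compounds shown alone.

Compound 1 `COc1cc2c(cc1O)CCC(C(=O)Nc1ccccc1)O2`: 6900 nM
Compound 2 `COc1cc2c(cc1O)C(=O)CC(C(=O)Nc1ccccc1)O2`: 293000 nM

In a functional assay (brain) for inhibition, with Rattus norvegicus as the target (on this read-out higher numbers stand for weaker inhibition and lower numbers for stronger inhibition), compound 2 has the higher number of the two, making it the weaker inhibitor, and its gap to compound 1 lies beyond the scatter. Compound 3 `CCCNC(=O)C1CC(=O)c2cc(O)c(OC)cc2O1` carries propyl in place of phenyl on an amide-type nitrogen. Going by the values given here, no measured pair shows this change, so the expectation rests only on compound 2 at 293000 nM. No step beyond the scatter is expected in this assay, with little certainty. The expected step is a 1.2-fold higher number from compound 2 to compound 3 (0.08 log units; within the scatter). For compound 3 the estimate is 350000 nM, with an expected range of 90000 nM to 1000000 nM.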

Compound 3, half-maximal inhibitory concentration: > 300000 nM
Compound 3: only a limit was reported; the forecaster's own chance of this, stated with the estimate: 20%; the middle value is on the limit's open side.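

In this assay compound 3 gives only a limit, > 300000 nM. Propyl in place of phenyl on the amide-type nitrogen gives an at least 1.0-fold higher number from compound 2 to compound 3 (0.01 log units; that floor lies within the scatter), so this change, the only one shown at this nitrogen, brings no lower number in this assay. The true size of the step stays unknown because the read-out ends at a limit: the limit of > 300000 nM in this assay, at which 1 of the 3 values shown sits.

Going by these compounds, whether a longer chain, a benzyl group or a chain ending in an amine on this nitrogen would give a lower number remains open. Also open, on these data alone, is how propyl would read on the core of compound 1.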